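The compounds below may be only part of what the source reports. "The series", "measured", "known", "first", "only" and "open" are said of these compounds alone.

In a functional assay on CCRF-CEM cells (Homo sapiens) for antiproliferative activity (on this read-out lower numbers stand for stronger inhibition of growth and higher numbers for weaker inhibition of growth), compound 1 (`COc1cc(-n2cc(-c3ccc(Cl)cc3)[nH]c2=O)cc(OC)c1OC`) gives < 10 nM, which is a limit of the assay and not a number. From the compounds shown here alone, its true value therefore remains unknown. In this assay, going by the values given here, compound 2 (`O=c1[nH]c(-c2ccc(Cl)c(Cl)c2)cn1-c1ccc(Cl)cc1`) gives 39800 nM, a far weaker result and the only other measurement available.

Compound 3 (`COc1cc(-n2cc(-c3ccccc3)[nH]c2=O)cc(OC)c1OC`) keeps the core of compound 1 but has hydrogen in place of chloro on an aromatic carbon, para to a large group, so that 4-chlorophenyl becomes phenyl: hydrogen in place of chloro on an aromatic carbon. Among the compounds with values here, no measured pair isolates this change, so the expectation for this assay is loose. A modest weakening of growth inhibition is expected, rather than a collapse of activity. The estimated change is an at least 3.0-fold higher number from compound 1 to compound 3 (0.47 log units; beyond the scatter). For compound 3 the expected value is 30 nM, with an estimated range from 6 nM to 300 nM.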

Compound 3, concentration for 50% growth inhibition: 63100 nM
The estimate for compound 3 lay 2100-fold (3.32 log units) below the measured number; the measured number lies above the stated range.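

Compound 1 and compound 3 form the only pair shown that differs in one place, and it shows that this position is far from tolerant on the shared core. In this assay, putting hydrogen in place of chloro on this aromatic carbon, para to a large group, gives an at least 6300-fold higher number from compound 1 to compound 3 (3.80 log units; beyond the scatter), so that one substituent separates strong from very weak inhibition of growth. The true size of the step remains open-ended, because the value for compound 1 is a limit of the assay and not a number: the limit of < 10 nM in this assay, at which 1 of the 3 values shown sits.

The compounds shown leave open whether chlorine itself is needed or whether fluoro, methyl or methoxy at this place would preserve the activity. They also do not show why the step is so large, or whether it would recur on another core.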